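The compounds below may be only part of what the source reports. "The series", "measured", "known", "first", "only" and "open" are said of these compounds alone.

In an ADME assay on L02 cells (Homo sapiens) for cytotoxicity, read by sulforhodamine B assay (on this read-out lower numbers stand for stronger inhibition and higher numbers for weaker inhibition), compound 1 `O=C1c2cccc3c2c(cc2c4ccccc4sc32)C(=O)N1CN1CCNCC1` stands at "not determined" (no result reported), and compound 2 `CCCCN1C(=O)c2cccc3c2c(cc2c4ccccc4sc32)C1=O` stands at "not determined" (no result reported). Compound 3 `CCCCN1C(=O)c2cccc3c2c(cc2c4ccccc4oc32)C1=O` gives > 100000 nM, which is a limit of the assay and not a number. The series therefore holds no exact value to work from. Compound 4 `CN(C)CCCN1C(=O)c2cccc3c2c(cc2c4ccccc4oc32)C1=O` differs from compound 3 by dimethylamino in place of methyl on a saturated chain carbon, three bonds along the chain from an amide-type nitrogen in a ring. Among the compounds with values here, no measured step gauges this change, so its size is a judgement. A move towards lower numbers in this assay, beyond the usual scatter, is expected, with an at least 8.3-fold lower number from compound 3 to compound 4 (0.92 log units; beyond the scatter) as the estimated step. For compound 4 the estimate is 12000 nM, with an expected range of 2500 nM to 70000 nM.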

Compound 4, half-maximal inhibitory concentration: 6600 nM
The estimate for compound 4 lay 1.8-fold (0.26 log units) above the measured number; the range from low to high includes it.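

In this assay, dimethylamino in place of methyl on a saturated chain carbon, three bonds along the chain from an amide-type nitrogen in a ring, gives a large move towards stronger inhibition, with an at least 15-fold lower number from compound 3 to compound 4 (1.18 log units; beyond the scatter). Within the data shown here, this position therefore responds strongly to the change, and compound 4 holds the only exact number. Compound 3 stands at a limit of the assay and not a number, so the size of the step is only a bound: the limit of > 100000 nM in this assay, at which 1 of the 4 values shown sits.

Open, from the compounds shown here alone, is whether the step follows the dimethylamino group itself, which a primary amine, a carboxylic acid or a longer chain at this place would test. Also open, going by these compounds, is whether the same change carries over to the core of compound 2.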